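Hydantoin series: phenyl for ethyl on the ring carbon

The compounds below may be only part of what the source reports. "The series", "measured", "known", "first", "only" and "open" are said of these compounds alone.

Compound 1 `O=C(NO)c1ccc(CN2C(=O)CN(Cc3ccccc3)C2=O)cc1` gives 12.5 nM in an assay on isolated protein for inhibition of protein deacetylase HDAC6 (Homo sapiens), read by fluorescence, with stated times of 10 min and 2 h; a lower number here means a stronger inhibitor, a higher number a weaker inhibitor. Compound 2 `CC(C)CC1C(=O)N(Cc2ccc(C(=O)NO)cc2)C(=O)N1C` gives 251 nM in this assay, and compound 3 `CCCN1C(=O)N(Cc2ccc(C(=O)NO)cc2)C(=O)C1CC(C)C` gives 174 nM in this assay. The one-place step a 1.4-fold lower number from compound 2 to compound 3 (0.16 log units; within the scatter) is within the scatter. Among the three numbers compound 3 stands second highest: compound 2 is its nearest neighbour, within the scatter, while compound 1 lies furthest, with a lower number beyond the scatter; no single-place step connects compound 1 to compound 3.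

Compound 4 `CC(C)CC1C(=O)N(Cc2ccc(C(=O)NO)cc2)C(=O)N1Cc1ccccc1` differs from compound 3 by phenyl in place of ethyl on a saturated chain carbon bound to an amide-type nitrogen in a ring. Among the compounds with values here, the only measured step at this place is a 1.4-fold lower number from compound 2 to compound 3 (0.16 log units; within the scatter), which was within the scatter; no measured pair covers ethyl to phenyl. On that basis no step beyond the scatter is expected in this assay for compound 4. The expected step is a 1.3-fold lower number from compound 3 to compound 4 (0.13 log units; within the scatter). Compound 4 is expected to give 130 nM, with a range of 40 nM to 400 nM.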

Compound 4, half-maximal inhibitory concentration: 129 nM
Estimate against measurement, compound 4: 1.0-fold (0.00 log units) above; the measured number falls inside the stated range.
By their numbers in this assay, from the lowest: compound 1; then compounds 4, 3 and 2 (each within the scatter of the next).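

At the place on a saturated chain carbon bound to an amide-type nitrogen in a ring, phenyl in place of ethyl gives a 1.3-fold lower number from compound 3 to compound 4 (0.13 log units; within the scatter) in this assay and shows that a six-membered aromatic ring of carbon can stand there with no step beyond the scatter. Phenyl in place of hydrogen gives a 1.9-fold lower number from compound 2 to compound 4 (0.29 log units; within the scatter) and is also within the scatter, so hydrogen, ethyl and phenyl at this place cannot be told apart in these numbers. The large step belongs to the other place, where isobutyl in place of hydrogen on a saturated ring carbon gives a 10-fold higher number from compound 1 to compound 4 (1.01 log units; beyond the scatter) and compound 4 stays well apart from compound 1.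

On these data alone, whether an amine or a carboxylic acid at the first place would also stay within the scatter remains open, as does whether methyl on the saturated ring carbon would give a step as large as isobutyl. No evidence on hand bears on the cause of either result.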